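The source may report more compounds than this note shows. Statements on the series, on what has been measured and on what is new or still open speak of the compounds shown alone.

Of the compounds shown here, three have been read so far in a functional assay on A549 cells (Homo sapiens) for cytotoxicity, read by MTT assay, with a stated time of 48 h; on this read-out lower numbers stand for stronger inhibition and higher numbers for weaker inhibition. Compound 1 `COc1cc(-n2c(-c3ccc(O)cc3)c[nH]c2=O)cc(OC)c1OC` sits at the limit of the assay, > 50000 nM. Compound 2 `COc1ccc(-c2cn(C(=O)Nc3cc(OC)c(OC)c(OC)c3)c(=O)n2-c2cc(OC)c(OC)c(OC)c2)cc1` sits at the same limit, > 50000 nM. Among the compounds with values here, compound 3 `COc1cc(-n2c(-c3ccc(Br)cc3)cn(C(C)=O)c2=O)cc(OC)c1OC` gives 1300 nM, the only actual number.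

Compound 4 `COc1ccc(-c2cn(C(C)=O)c(=O)n2-c2cc(OC)c(OC)c(OC)c2)cc1N` keeps the acetyl group of compound 3, and 3-amino-4-methoxyphenyl takes the place of 4-bromophenyl on an aromatic carbon (3-amino-4-methoxyphenyl in place of 4-bromophenyl on an aromatic carbon). Within the data shown here, no measured step gauges this exchange, so the expectation is a judgement with wide uncertainty: stronger inhibition in this assay, by a step well beyond the scatter. The estimated step runs a 13-fold lower number from compound 3 to compound 4 (1.11 log units; beyond the scatter). For compound 4 the expected value is 100 nM, with an estimated range of 10 nM to 1500 nM.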

Compound 4, half-maximal inhibitory concentration: 1100 nM
Estimate against measurement, compound 4: 11-fold (1.04 log units) below, within the range that was stated.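

In this assay the exchange on this aromatic carbon reads as a 1.2-fold lower number from compound 3 to compound 4 (0.07 log units; within the scatter) and so gives no readable change. With the acetyl group kept, 4-bromophenyl and 3-amino-4-methoxyphenyl thus read alike here, although the entering group brings an amino and a methoxy group and the leaving group a bromine.

On these data alone, whether a carboxylic acid or a longer chain on this carbon, or a free amine in place of the acetyl group, would move the number stays open. Nothing shown gives a cause for this flat step.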